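This account rests on a few compounds, and the source may have more. Where it says the series, first, only, none or still open, it means among the compounds named here.

Working notes on the series sharing one core.

Compound 1 `C#CCSc1nc(Nc2ccccc2)c2ccncc2n1` is the unsubstituted parent. In a functional assay on MGC-803 cells (Homo sapiens) for inhibition, read by MTT assay, with a stated time of 72 h (a higher number here means a weaker inhibitor, a lower number a stronger inhibitor), compound 1 gives 16200 nM. Among the three compounds measured, compound 1 stands second highest; compound 2 `C#CCSc1nc(Nc2ccccc2Cl)c2ccncc2n1` gives 27600 nM, and compound 3 `C#CCSc1nc(Nc2cc(OC)c(OC)c(OC)c2)c2ccncc2n1` gives 5680 nM, which is the lowest number of the three and lies beyond the scatter from compound 1.

Going by the values given here, the single measured step, a 1.7-fold higher number from compound 1 to compound 2 (0.23 log units; within the scatter), is within the scatter, so the chloro substitution on the aromatic ring shows no clear effect on this assay.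

Compound 4 `C#CCSc1nc(Nc2cccc(O)c2)c2ccncc2n1` differs from compound 1 by hydroxy in place of hydrogen on an aromatic carbon. Among the compounds with values here, no measured pair carries this same change, so the only guide is indirect: compound 3, with its three methoxy groups on the same ring, reads lower than compound 1 in this assay, while the ortho chloro of compound 2 changes nothing beyond the scatter. A hydroxy on the ring is a different kind of group from either, and the direction it takes cannot be fixed from these three compounds alone.

For compound 4 the step of a 1.6-fold lower number from compound 1 to compound 4 (0.21 log units; within the scatter) is therefore expected to be modest, leaning toward a lower number, without confidence that it clears the scatter. Compound 4 is estimated at 10000 nM, with a range from 3500 nM to 30000 nM.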

Compound 4, half-maximal inhibitory concentration: 15700 nM
Beside the measured number, compound 4's estimate is 1.6-fold (0.20 log units) below it; the measured number falls inside the stated range.
By their numbers in this assay, from the lowest: compound 3; then compounds 4, 1 and 2 (each within the scatter of the next).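

In this assay, going by these compounds alone, the step of a 1.0-fold lower number from compound 1 to compound 4 (0.01 log units; within the scatter) shows that hydroxy on an aromatic carbon, meta to a large group, leaves the number of the unsubstituted parent unmoved within the scatter; this is the first reading at this position, and the change from phenyl to 3-hydroxyphenyl alone gives no measurable gain or loss here. The step of a 1.8-fold lower number from compound 2 to compound 4 (0.25 log units; within the scatter) also stays within the scatter, so 3-hydroxyphenyl and 2-chlorophenyl on the nitrogen cannot be told apart in this assay. Nothing at hand explains why the number stays flat with this change.

Whether this flat reading is particular to hydroxy or holds for this position in general remains open, as the compounds shown carry no other single group meta to the large group, such as an amine, a carboxylic acid or a longer chain like ethoxy. Going by these compounds, it is also open whether hydroxy would read the same at another place on the ring, since the series shows it at only one.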